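The source may hold more compounds than are shown below. What is called first, only, known or untested is meant among the compounds shown, and "the series" means these compounds.

Measured compounds:
- compound 1 `Cc1cc(C)n2nc(S(=O)(=O)Nc3c(Br)ccc4cccnc34)nc2n1`: 8.7 nM
- compound 2 `Cc1ccn2nc(S(=O)(=O)Nc3c(Br)ccc4cccnc34)nc2n1`: 19.2 nM

Both were tested in an assay for inhibition of acetolactate synthase (Nicotiana tabacum); on this read-out higher numbers stand for weaker inhibition and lower numbers for stronger inhibition. In this assay compound 1 gives 8.7 nM, the lowest of the two numbers. Among the measured compounds shown here, compound 2 gives 19.2 nM; the one measured step, a 2.2-fold higher number from compound 1 to compound 2 (0.34 log units; beyond the scatter), concerns hydrogen in place of methyl on an aromatic carbon.

Compound 3 `Cc1cc(C)n2nc(S(=O)(=O)Nc3c(F)ccc4cccnc34)nc2n1` is not yet measured. It differs from compound 1 in one place: fluoro in place of bromo on an aromatic carbon. For the measured compounds named here, no measured step bears on an exchange of one halogen for another; the only step known, a 2.2-fold higher number from compound 1 to compound 2 (0.34 log units; beyond the scatter), changes a different part of the shared core and so gives no direct guide. With nothing against a change and nothing for a large one, a step in this assay of a 1.7-fold higher number from compound 1 to compound 3 (0.24 log units; within the scatter) is expected, small and of uncertain direction. For compound 3 the estimated value is 15 nM, with a range from 5 nM to 45 nM.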

Compound 3, half-maximal inhibitory concentration: 7.7 nM
For compound 3 the middle estimate is 1.9-fold (0.29 log units) above the measured one; measured number inside the range.
By their numbers in this assay, from the lowest: compounds 3 and 1 (each within the scatter of the next); then compound 2.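

In this assay, the exchange gives a 1.1-fold lower number from compound 1 to compound 3 (0.05 log units; within the scatter), so the numbers for bromo and fluoro on this aromatic carbon cannot be told apart. Among the compounds shown here, the earlier step changed only a methyl elsewhere on the shared core, so this is the first reading at this position, and it shows that these two halogens serve equally well there in this assay. Nothing measured here explains this match between the two halogens.

On these data alone, two halogens say little about other kinds of group, so it remains open whether an amine, a methoxy group or a carboxylic acid on this same carbon would keep the number in this range. Also open, as far as these compounds go, is whether removing the methyl would matter as much with fluoro present as it did with bromo, where it gave a 2.2-fold higher number from compound 1 to compound 2 (0.34 log units; beyond the scatter).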